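Furan Amide Replaces Fluorophenyl Amide on a Thiazole Carboxamide Series

A few compounds are considered here, and "the series" means these few. Any claim that something is new, unique, unknown or untested is made for them only; others in the source may bear on it.

Compound 1: `CCOC(=O)c1sc(-c2cccc(NC(=O)c3ccc(F)cc3)c2)nc1Nc1ccc(N2CCN(C)CC2)cc1` — "not determined" (no result reported).
Compound 2: `CCOC(=O)c1sc(-c2cccc(NC(=O)c3ccccc3)c2)nc1Nc1ccc(N2CCN(C)CC2)cc1` — 24800 nM.
Compound 3: `CN1CCN(c2ccc(Nc3nc(-c4cccc(NC(=O)c5ccc(F)cc5)c4)sc3C(N)=O)cc2)CC1` — 1420 nM.

In a functional assay on Ramos cells (Homo sapiens) for antiproliferative activity, read by CCK-8 assay, with a stated time of 72 h (on this read-out higher numbers stand for weaker inhibition and lower numbers for stronger inhibition), compound 3 gives the lowest of the two numbers on record; its nearest neighbour, compound 2, sits well beyond the scatter of repeated measurements, and compound 1 contributes no number at all. Compound 4, `CN1CCN(c2ccc(Nc3nc(-c4cccc(NC(=O)c5ccco5)c4)sc3C(N)=O)cc2)CC1`, keeps the core of compound 3 and differs in one place: furan-2-yl in place of 4-fluorophenyl on a carbonyl carbon. Among the compounds with values here, no measured pair in this set isolates that change, so its size is unknown here. Compound 4 is expected to lie close to compound 3, with a step of a 1.8-fold higher number from compound 3 to compound 4 (0.25 log units; within the scatter) toward a somewhat higher number in this assay. The estimate for compound 4 is 2500 nM, ranging from 800 nM to 8000 nM.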

Compound 4, half-maximal inhibitory concentration: 19700 nM
Compound 4: the middle estimate sits 7.9-fold (0.90 log units) below what was measured; measured number above the stated range.
By their numbers in this assay, from the lowest: compound 3; then compounds 4 and 2 (each within the scatter of the next).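

In this assay, furan-2-yl in place of 4-fluorophenyl on a carbonyl carbon gives a 14-fold higher number from compound 3 to compound 4 (1.14 log units; beyond the scatter). Within the data shown here, this is the first measured step in the set that isolates a change at this place, and it shows that the group there strongly affects the read-out, with 4-fluorophenyl giving the lower number of the two. No measurement at hand explains the step.

As far as these compounds go, whether phenyl, thiophen-2-yl or cyclohexyl on the same carbonyl carbon would give a number closer to that of compound 3 remains open. So does whether furan-2-yl would have a similar effect on the ethyl ester compounds.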